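From methylsulfanyl to methylsulfonyl on a shared core

A few compounds are considered here, and "the series" means these few. Any claim that something is new, unique, unknown or untested is made for them only; others in the source may bear on it.

Among the measured compounds shown here, compound 1, `CSc1cccc2c(=O)c(-c3nn[nH]n3)c[nH]c12`, is the only compound here with a number in a functional assay on the whole organism (strain Sprague-Dawley) for inhibition, with Rattus norvegicus as the target; on this read-out lower numbers stand for an effect already at smaller amounts and higher numbers for an effect only at larger amounts of compound: compound 1 gives 10 mg/kg. The other measured compound, compound 2, `COc1ccc2ncc(C(=O)O)cc2c1`, is recorded only as a limit of this assay, and compound 2 gives > 5 mg/kg, which is a limit and not a number. That is the limit of > 5 mg/kg in this assay, at which 1 of the 2 values shown sits. For the measured compounds named here, no pair of measured compounds differing in one place is available, so compound 1 stands alone on its number, with nothing to rank it against.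

Compound 3, `CS(=O)(=O)c1cccc2c(=O)c(-c3nn[nH]n3)c[nH]c12`, differs from compound 1 in one place: methylsulfonyl in place of methylsulfanyl on an aromatic carbon. Going by the values given here, nothing among the measured compounds shows how this change moves the minimum effective dose, so no direction can be read from the data. The change in this assay is therefore expected to be no change at the digits printed from compound 1 to compound 3 (within the scatter), none beyond the usual scatter in either direction. Compound 3 is estimated to give 10 mg/kg in this assay, with a range from 3 mg/kg to 30 mg/kg.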

Compound 3, minimum effective dose: 10 mg/kg
Estimate against measurement, compound 3: no gap at the digits printed; the measured number falls inside the stated range.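

Among the compounds shown here, the first comparison at this position comes from methylsulfonyl taking the place of methylsulfanyl on an aromatic carbon of the shared core, and in this assay the step reads no change at the digits printed from compound 1 to compound 3 (within the scatter). The earlier compounds shown here offered no pair from which to read any such step, and this one shows that the minimum effective dose stays the same here even though the entering group has 4 heavy atoms and 2 hydrogen-bond acceptors, where the leaving group had 2 heavy atoms and 1 hydrogen-bond acceptor. Nothing measured here explains why the two compounds read alike.

As far as these compounds go, whether an amine, a carboxylic acid or a longer chain such as ethylsulfonyl on the same aromatic carbon would also leave the minimum effective dose within the scatter remains open. A single step at one position also says nothing about changes elsewhere on the shared core, or about whether the same exchange would read alike on a different core.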